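Solubility notes on a methoxy-to-hydrogen change

The compounds below may be only part of what the source reports. "The series", "measured", "known", "first", "only" and "open" are said of these compounds alone.

Measured so far in a physicochemical assay for solubility, read by spectrophotometry, with stated times of 1 h and 30 min; a higher number here means a more soluble compound, a lower number a less soluble compound:
- compound 1 `COc1ccccc1/C=C/C=C/C(=O)c1ccc([N+](=O)[O-])cc1` gives 13.9 ug/mL 
- compound 2 `COc1ccccc1/C=C/C=C/C(=O)c1cc(OC)c(OC)c(OC)c1` gives 25.9 ug/mL 

With only these two numbers, compound 2 stands within the usual scatter of compound 1, so the two cannot be ranked. For the measured compounds named here, no measured pair yet differs in one place only, so nothing calibrates a single change. Compound 3 `COc1cc(C(=O)/C=C/C=C/c2ccccc2)cc(OC)c1OC` has no number yet. It differs from compound 2 in one place (hydrogen in place of methoxy on an aromatic carbon) with hydrogen in place of methoxy on an aromatic carbon, ortho to a large group, which also reads as 2-methoxyphenyl to phenyl. As far as these compounds go, no shift beyond the scatter is expected in this assay, and the direction remains open. The expected change is small (a 1.2-fold lower number from compound 2 to compound 3 (0.07 log units; within the scatter)) and lies inside the scatter. For compound 3 the estimated value is 22 ug/mL (expected range 10 ug/mL to 45 ug/mL).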

Compound 3, solubility: 20.3 ug/mL
Compound 3: middle estimate off by 1.1-fold (0.03 log units), on the high side; measured number inside the range.
By their numbers in this assay, from the lowest: compounds 1, 3 and 2 (each within the scatter of the next).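

In this assay, for the compounds shown here, hydrogen in place of methoxy on an aromatic carbon, ortho to a large group, gives a 1.3-fold lower number from compound 2 to compound 3 (0.11 log units; within the scatter) and so provides the first single-place step. That step lies within the scatter, so the two compounds cannot be ranked and this position shows no resolved response to the change, which also reads as 2-methoxyphenyl to phenyl. No supporting measurement bears on this result, and no explanation can be attached to it.

Still open, as far as these compounds go, is whether an amine, a carboxylic acid or a longer alkoxy chain at this position would give a step beyond the scatter. Also open, from the compounds shown here alone, is whether the same methoxy-to-hydrogen change would stay within the scatter on the core of compound 1, where the other aromatic ring carries a nitro group.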